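Removing the Carbamoyl Group from a Cathepsin S Inhibitor

This account rests on a few compounds, and the source may have more. Where it says the series, first, only, none or still open, it means among the compounds named here.

Measured compounds:
compound 1, `N#Cc1ncc2cc(COc3ccc(C(N)=O)cc3)n(CCC3CCCCC3)c2n1`, 2 nM
compound 2, `CC(C)(C)CCn1c(Cc2ccc(Cl)cc2)cc2cnc(C#N)nc21`, 2 nM

Both compounds were tested in an assay on isolated protein for inhibition of cathepsin S (Homo sapiens), read by fluorescence; on this read-out higher numbers stand for weaker inhibition and lower numbers for stronger inhibition. In this assay compound 1 gives 2 nM and compound 2 gives 2 nM; the two values are the same at the digits shown, so compound 1 stands level with compound 2, with no difference beyond the scatter.

Compound 3, `N#Cc1ncc2cc(COc3ccccc3)n(CCC3CCCCC3)c2n1`, has not yet been measured. It differs from compound 1 in one place: hydrogen in place of carbamoyl on an aromatic carbon. Going by the values given here, no step between two measured compounds covers this change, so the expectation rests on what the two measured compounds show. Compound 2 carries no carbamoyl at all and still gives 2 nM, which suggests that strong inhibition does not depend on this group. A small loss within or slightly beyond the scatter is therefore expected, and the step from compound 1 to compound 3 is estimated at a 2.5-fold higher number from compound 1 to compound 3 (0.40 log units; beyond the scatter). For compound 3 the expected value in this assay is 5 nM, with a range from 1.5 nM to 20 nM.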

Compound 3, half-maximal inhibitory concentration: 10 nM
Estimate against measurement, compound 3: 2.0-fold (0.30 log units) below, within the range that was stated.
By their numbers in this assay, from the lowest: compounds 1 and 2 (each within the scatter of the next); then compound 3.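

Replacing 4-carbamoylphenoxy with phenoxy gives, in this assay, a 5.0-fold higher number from compound 1 to compound 3 (0.70 log units; beyond the scatter), a step beyond the scatter, which shows that the carbamoyl group on this aromatic carbon contributes measurably to inhibition of the enzyme in this series. The group is helpful here but not indispensable, since compound 3 still gives 10 nM without it, so the phenoxy compound remains a clear inhibitor in its own right. No separate measurement is available to explain why the loss occurs.

Going by these compounds alone, the single change does not tell whether the loss comes from the carbonyl or the amide hydrogens of the carbamoyl group, and a carboxylic acid, a nitrile, a methyl ester or an aminomethyl group on the same carbon would help separate those possibilities. From the compounds shown here alone, it also remains open whether a carbamoyl group on a different carbon of this ring would perform as well, and whether removing it would cost the same with a different chain in place of the cyclohexylethyl group.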